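The source may report more compounds than this note shows. Statements on the series, on what has been measured and on what is new or still open speak of the compounds shown alone.

Compound 1 `O=C1NC(=O)/C(=C/C(c2ccc(-c3ccc4cccc(F)c4c3)[nH]c2=O)C2CC2)O1` is one of two measured members of the series. In an assay on membranes from Chem-1 cells for displacement of a labelled ligand from prostaglandin E2 receptor EP3 subtype (Homo sapiens), read by scintillation counting, with a stated time of 2 h (on this read-out lower numbers stand for stronger inhibition and higher numbers for weaker inhibition), compound 1 gives 22 nM. Compound 2 `CC(C)[C@@H](c1ccc(-c2ccc3cccc(F)c3c2)[nH]c1=O)[C@H]1OC(=O)NC1=O` is the other measured member; in this assay compound 2 gives 27 nM. Going by the values given here, of the two numbers the one for compound 1 is the lowest, but its gap to compound 2 lies within the usual scatter, so the two compounds are not separated by these data.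

Compound 3 `O=C1NC(=O)/C(=C/C(c2ccc(-c3ccc4cccc(F)c4c3)[nH]c2=O)C2CCCCC2)O1` has not yet been measured. It differs from compound 1 in a single place: cyclohexyl in place of cyclopropyl on a saturated chain carbon bound to an aromatic carbon and a double-bonded chain carbon. Among the compounds with values here, no measured pair changes this group, so the size of the step is not anchored by any recorded measurement. The two recorded values are close to each other, and nothing in the data points to a large shift in either direction for this kind of change.

Compound 3 is expected to show a step of a 1.8-fold higher number from compound 1 to compound 3 (0.26 log units; within the scatter), a modest move toward a weaker number that may still fall within the scatter. The estimate for compound 3 in this assay is 40 nM, with a range from 12 nM to 130 nM.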

Compound 3, inhibition constant: 4 nM
Estimate against measurement, compound 3: 10-fold (1.00 log units) above, and the stated range ends above it.
By their numbers in this assay, from the lowest: compound 3; then compounds 1 and 2 (each within the scatter of the next).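

In this assay, going by these compounds alone, the saturated chain carbon bound to an aromatic carbon and a double-bonded chain carbon responds clearly to the group it carries: cyclohexyl in place of cyclopropyl gives a 5.5-fold lower number from compound 1 to compound 3 (0.74 log units; beyond the scatter) as the first step to read beyond the scatter. The step runs toward stronger inhibition, so this place accepts the six-membered carbon ring with its 6 heavy atoms, where compound 1 carries the three-membered ring with 3, and the larger ring brings a real gain rather than a loss. Within the data shown here, nothing measured so far bears on the reason for this gain, so the step stands as an observation only.

Among these compounds, only two ring sizes are compared at this place, so it remains open whether the number keeps falling, levels off or rises again with groups such as cyclopentyl, cycloheptyl, phenyl or a cyclohexyl ring carrying an amine. Also open, as far as these compounds go, is whether the gain from cyclohexyl carries over to the core of compound 2, or is tied to the core shared by compound 1 and compound 3.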